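Carbamate to benzoate on the dihydronaphthalene phenol

The compounds below may be only part of what the source reports. "The series", "measured", "known", "first", "only" and "open" are said of these compounds alone.

Measured so far:
- compound 1, `COc1cccc(C(=O)Oc2cc3c(cc2C)[C@@H](C(C)C)CC=C3C)c1`: "not active" (no number reported)
- compound 2, `CC1=CC[C@H](C(C)C)c2cc(C)c(OC(=O)Nc3ccccc3)cc21`: 92.6%
- compound 3, `Cc1cc2c(C(C)C)ccc(C)c2cc1OC(=O)c1ccc(C(F)(F)F)cc1`: 45.1%

Compound 2 holds the highest of the two numbers in a functional assay on K562 cells (Homo sapiens) for antiproliferative activity, read by sulforhodamine B assay, with a stated time of 48 h, tested at 50 uM; a higher number here means more inhibition at the concentration tested (going by the name of the read-out), a lower number less inhibition; the nearest entry with a number is compound 3, which sits well below it, beyond the scatter. Compound 1 carries the same shared core as compound 2 but is reported without a number in this assay. For the measured compounds named here, no two of the measured compounds differ in only one place, so no single step has been measured yet.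

Compound 4, `CC1=CC[C@H](C(C)C)c2cc(C)c(OC(=O)c3ccccc3)cc21`, is the next entry to be measured in this assay. Relative to compound 2 the change is phenyl in place of anilino on a carbonyl carbon: the carbamate becomes a benzoate ester.

Compound 1, an ester with a methoxy-substituted benzoyl group on the same core, gave no number, and compound 3, an ester on a different core, gave 45.1%. Both esters stand well under the carbamate compound 2. On that basis a drop beyond the scatter is expected for the step from compound 2 to compound 4, estimated as a number 62.6 percentage points lower from compound 2 to compound 4 (beyond the scatter).

For compound 4 in this assay the estimate is 30%, expected to fall between 5% and 60%.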

Compound 4, a percentage reported as inhibition, at one concentration (the size of the read-out at that concentration, not a potency): "not active" (no number reported)
Nothing numeric was reported for compound 4, so the estimate cannot be set against anything.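

Compound 4 is reported without a number, so the step from compound 2, anilino to phenyl on the carbonyl carbon, cannot be read as a size. No measured evidence bears on this result.
The compounds shown leave open how large the change from the carbamate of compound 2 to the benzoate of compound 4 is.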